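Chain Extension on the Pyrazole Analogue: Expected Potency

A few compounds are considered here, and "the series" means these few. Any claim that something is new, unique, unknown or untested is made for them only; others in the source may bear on it.

compound 1, `CCNC(=O)c1noc(-c2cc(C(C)C)c(O)cc2O)c1-c1cc(C(=O)NC)no1`: 124 nM
compound 2, `CCNC(=O)c1cc(-c2c(C(=O)NCC)noc2-c2cc(C(C)C)c(O)cc2O)on1`: 14 nM
compound 3, `CCNC(=O)c1noc(-c2cc(C(C)C)c(O)cc2O)c1-c1ccn(CC)n1`: 25 nM

These three compounds were measured in a functional assay on HCT-116 cells (Homo sapiens) for inhibition; on this read-out lower numbers stand for stronger inhibition and higher numbers for weaker inhibition. Compound 4, `CCCn1ccc(-c2c(C(=O)NCC)noc2-c2cc(C(C)C)c(O)cc2O)n1`, has not yet been measured there. The core of compound 3 and compound 4 differs from the core of compound 1 by 1-ethyl-1H-pyrazol-3-yl in place of 3-(methylcarbamoyl)-1,2-oxazol-5-yl on an aromatic carbon. The change from compound 3 to compound 4 is methyl in place of hydrogen on a saturated chain carbon, two bonds along the chain from an aromatic nitrogen. The same kind of change, (methyl in place of hydrogen on a saturated chain carbon bound to an amide-type nitrogen), gave an 8.9-fold lower number from compound 1 to compound 2 (0.95 log units; beyond the scatter). The two places are not the same: in the first case the carbon is bound to an amide-type nitrogen, here it lies two bonds along the chain from an aromatic nitrogen. Resting on a single earlier instance at a different place, a smaller step is expected for compound 4, a 1.7-fold lower number from compound 3 to compound 4 (0.22 log units; within the scatter). Compound 4 is estimated at 15 nM, with a range from 5 nM to 45 nM.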

Compound 4, half-maximal inhibitory concentration: 49 nM
The estimate for compound 4 lay 3.3-fold (0.51 log units) below the measured number, outside the stated range (above it).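

In this assay, the added methyl gave a 2.0-fold higher number from compound 3 to compound 4 (0.29 log units; within the scatter), so the large step seen earlier did not carry over to the 1-ethyl-1H-pyrazol-3-yl series: the same change on two cores in this assay, an 8.9-fold lower number (0.95 log units; beyond the scatter) from compound 1 to compound 2 and a 2.0-fold higher number (0.29 log units; within the scatter) from compound 3 to compound 4, 17-fold (1.24 log units) apart, beyond the scatter of two such steps

With the 1-propyl-1H-pyrazol-3-yl group in place, the other comparisons read a 3.5-fold higher number from compound 2 to compound 4 (0.54 log units; beyond the scatter) and a 2.5-fold lower number from compound 1 to compound 4 (0.40 log units; beyond the scatter). The two methyl steps sit at different places, one on a carbon bound to an amide-type nitrogen and the other two bonds along the chain from an aromatic nitrogen, so this single pair of steps does not separate an effect of core from one of place.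

The compounds shown leave open how a butyl chain in place of the propyl chain would read. They also leave open how a terminal amine or carboxylic acid on that chain would read.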